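The source may hold more compounds than are shown below. What is called first, only, known or untested is meant among the compounds shown, and "the series" means these compounds.

Three close relatives of one shared core have been tested in a functional assay on MCF7 cells (Homo sapiens) for cytotoxicity, read by MTT assay, with a stated time of 72 h; a lower number here means a stronger inhibitor, a higher number a weaker inhibitor. Compound 1 `Cc1ccc(-c2ccc(C)n2-c2ccc(-c3nc4ccccc4s3)cc2)cc1` gives 3100 nM. Compound 2 `Cc1ccc(-c2ccc(C)n2-c2ccc(-c3nc4ccc(F)cc4s3)cc2)cc1` gives 2970 nM, the second highest of the three numbers, and compound 3 `Cc1ccc(-c2ccc(F)cc2)n1-c1ccc(-c2nc3ccc(F)cc3s2)cc1` gives 2800 nM. The step of a 1.0-fold lower number from compound 1 to compound 2 (0.02 log units; within the scatter) put fluoro in place of hydrogen on an aromatic carbon, and the step of a 1.1-fold lower number from compound 2 to compound 3 (0.03 log units; within the scatter) put fluoro in place of methyl on an aromatic carbon; both stayed within the scatter. Compound 4 `COc1ccc2nc(-c3ccc(-n4c(C)ccc4-c4ccc(C)cc4)cc3)sc2c1` differs from compound 2 by methoxy in place of fluoro on an aromatic carbon. Since both earlier changes at aromatic carbons left this assay unchanged beyond the scatter, the expected step is a 1.0-fold higher number from compound 2 to compound 4 (0.00 log units; within the scatter), again within the scatter. For compound 4 the estimate is 3000 nM, with a range from 1500 nM to 6000 nM.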

Compound 4, half-maximal inhibitory concentration: 2850 nM
For compound 4 the middle estimate is 1.1-fold (0.02 log units) above the measured one, within the range that was stated.
By their numbers in this assay, from the lowest: compounds 3, 4, 2 and 1 (each within the scatter of the next).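

Methoxy at this position counts as a hydrogen-bond acceptor where fluoro and hydrogen do not, yet in this assay the step is a 1.0-fold lower number from compound 2 to compound 4 (0.02 log units; within the scatter) for methoxy in place of fluoro and a 1.1-fold lower number from compound 1 to compound 4 (0.04 log units; within the scatter) for methoxy in place of hydrogen. Both steps stay within the scatter, so all three groups at this position give matching results in this assay. No measurement shown offers an explanation for this result. Going by these compounds, whether an amine, a carboxylic acid or a longer chain such as butoxy here would move the number beyond the scatter stays open.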